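Swapping the Basic Side Chain for an Amide

The compounds below may be only part of what the source reports. "The series", "measured", "known", "first", "only" and "open" are said of these compounds alone.

Measured so far in a functional assay on SW480 cells (Homo sapiens) for antiproliferative activity, read by MTT assay, with a stated time of 48 h; a lower number here means a stronger inhibitor, a higher number a weaker inhibitor:
Compound 1 `COC/C1=C/C[C@](C)(CCC=C(C)C)/C=C/[C@@H](OC(=O)C=C(C)C)[C@](C)(O)/C=C/C1=O` gives 3850 nM.
Compound 2 `CC(C)=CCC[C@]1(C)/C=C/[C@@H](OC(=O)C=C(C)C)[C@](C)(O)/C=C/C(=O)/C(C(=O)O)=C\C1` gives only a limit of the assay, > 10000 nM.
Compound 3 `CC(C)=CCC[C@]1(C)/C=C/[C@@H](OC(=O)C=C(C)C)[C@](C)(O)/C=C/C(=O)/C(CN2CCCC2)=C\C1` gives 310 nM.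

Compound 3 stands lowest of the two numbers; the nearest number belongs to compound 1, and a 12-fold lower number from compound 1 to compound 3 (1.09 log units; beyond the scatter). Compound 4 `CC(C)=CCC[C@]1(C)/C=C/[C@@H](OC(=O)C=C(C)C)[C@](C)(O)/C=C/C(=O)/C(C(=O)N(C)C)=C\C1` differs from compound 3 in one place: dimethylcarbamoyl in place of (pyrrolidin-1-yl)methyl on a double-bonded ring carbon. Among the measured compounds shown here, two measured steps bear on this change: an at least 32-fold lower number from compound 2 to compound 3 (1.50 log units; beyond the scatter) and a 12-fold lower number from compound 1 to compound 3 (1.09 log units; beyond the scatter), both large drops when the (pyrrolidin-1-yl)methyl group entered. Its loss, for a group that, like carboxy, has no ring, is therefore expected to give back much of that gain: a 9.7-fold higher number from compound 3 to compound 4 (0.99 log units; beyond the scatter). Compound 4 is estimated at 3000 nM, between 800 nM and 10000 nM.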

Compound 4, half-maximal inhibitory concentration: 3300 nM
The estimate for compound 4 lay 1.1-fold (0.04 log units) below the measured number; low and high end bracket the measured number.
By their numbers in this assay, from the lowest: compound 3; then compounds 4 and 1 (each within the scatter of the next). At a limit, above all of these: compound 2.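

Dimethylcarbamoyl in place of (pyrrolidin-1-yl)methyl gives an 11-fold higher number from compound 3 to compound 4 (1.03 log units; beyond the scatter), so the gain at this double-bonded ring carbon is lost with this swap. Dimethylamino in place of hydroxy on the carbonyl carbon gives an at least 3.0-fold lower number from compound 2 to compound 4 (0.48 log units; beyond the scatter), while the amide and the methoxymethyl group of compound 1 cannot be told apart, with a 1.2-fold lower number from compound 1 to compound 4 (0.07 log units; within the scatter). Compound 2 stands at a limit of the assay, so its step is only a bound: the limit of > 10000 nM in this assay, at which 1 of the 4 values shown sits.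

Going by these compounds, whether the gain follows the amine or the ring stays open. A (dimethylamino)methyl group would keep the amine without the ring, and a (pyrrolidin-1-yl)carbonyl group would keep the ring without the amine.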